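Swapping the aryl group on the carbonyl carbon

A few compounds are considered here, and "the series" means these few. Any claim that something is new, unique, unknown or untested is made for them only; others in the source may bear on it.

Among the measured compounds shown here, compound 2 `COc1ccc(C(=O)/C=C/c2cc(-c3cc(OC)c(OC)c(OC)c3)n[nH]2)cc1OC` gives 880 nM in a functional assay on HCT-116 cells (Homo sapiens) for inhibition, read by sulforhodamine B assay, with a stated time of 48 h (a higher number here means a weaker inhibitor of growth, a lower number a stronger inhibitor of growth), the lower of the two numbers so far, although its nearest neighbour, compound 1 `COc1cc(-c2cc(/C=C/C(=O)c3ccc(N)cc3)[nH]n2)cc(OC)c1OC`, is within the scatter and in this assay compound 1 gives 1100 nM. Compound 3 `COc1cc(-c2cc(/C=C/C(=O)c3ccc(F)c(F)c3)[nH]n2)cc(OC)c1OC` carries a new ring on the same position: 3,4-difluorophenyl in place of 3,4-dimethoxyphenyl on a carbonyl carbon. For the measured compounds named here, only one measured step bears on such an exchange on the carbonyl carbon, and because a 1.3-fold lower number from compound 1 to compound 2 (0.10 log units; within the scatter) stayed within the scatter, little movement is expected here too, namely a 1.1-fold higher number from compound 2 to compound 3 (0.06 log units; within the scatter). Compound 3 is therefore estimated at 1000 nM, within a range from 400 nM to 2500 nM.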

Compound 3, concentration for 50% growth inhibition: 4000 nM
Compound 3: middle estimate off by 4.0-fold (0.60 log units), on the low side; measured number above the stated range.
By their numbers in this assay, from the lowest: compounds 2 and 1 (each within the scatter of the next); then compound 3.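

In this assay, the group on the carbonyl carbon proves able to shift the number: 3,4-difluorophenyl in place of 3,4-dimethoxyphenyl gives a 4.5-fold higher number from compound 2 to compound 3 (0.66 log units; beyond the scatter), and 3,4-difluorophenyl in place of 4-aminophenyl gives a 3.6-fold higher number from compound 1 to compound 3 (0.56 log units; beyond the scatter). Both steps lie beyond the scatter, unlike the earlier exchange between the two rings without fluorine, so this position is not indifferent to every ring it carries. No measurement at hand explains this rise. Still open, as far as these compounds go, is what a ring bearing a single fluorine, or a carboxylic acid, would give on this carbonyl carbon.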